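The source may hold more compounds than are shown below. What is called first, only, known or untested is meant among the compounds shown, and "the series" means these compounds.

In a functional assay on KYSE-450 cells (Homo sapiens) for inhibition, read by CCK-8 assay, with a stated time of 48 h (a lower number here means a stronger inhibitor, a higher number a weaker inhibitor), compound 1 `COc1cc(N(Cc2ccc(Br)cc2)C(=O)CSC(=S)N2CCN(C(=O)OC(C)(C)C)CC2)cc(OC)c1OC` gives 10700 nM. Compound 2 `COc1ccc(CN(C(=O)CSC(=S)N2CCN(C(=O)OC(C)(C)C)CC2)c2cc(OC)c(OC)c(OC)c2)cc1OC` gives > 20000 nM, which is a limit of the assay and not a number. Its standing is therefore known only as the limit of > 20000 nM in this assay, at which 1 of the 2 values shown sits.

Among the measured compounds shown here, the single measured step, with 3,4-dimethoxyphenyl in place of 4-bromophenyl, is an at least 1.8-fold higher number from compound 1 to compound 2 (0.27 log units; that floor lies within the scatter). It is a weak guide, and it is the only one available.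

Compound 3 `COc1ccc(CN(C(=O)CSC(=S)N2CCN(C(=O)OC(C)(C)C)CC2)c2cc(OC)c(OC)c(OC)c2)cc1Br` differs from compound 2 by one change, (bromo in place of methoxy on an aromatic carbon). This is bromo in place of methoxy on an aromatic carbon, ortho to a methoxy group, so that 3,4-dimethoxybenzyl becomes 3-bromo-4-methoxybenzyl.

Compound 3 thus regains a bromo, as carried by compound 1 at 10700 nM, so a number near that value is expected in this assay. The bromo sits at a different place on the ring, however, and a result at the limit remains possible.

The expected change is an at least 1.8-fold lower number from compound 2 to compound 3 (0.25 log units; that floor lies within the scatter), towards a lower number and of modest size. The estimate for compound 3 is 11000 nM, with an expected range from 4000 nM to 20000 nM.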

Compound 3, half-maximal inhibitory concentration: 1850 nM
The estimate for compound 3 lay 5.9-fold (0.77 log units) above the measured number; measured number outside the range, below it.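

In this assay, exchanging one methoxy for bromo on the benzyl ring, on the aromatic carbon ortho to a methoxy group, gives an at least 10-fold lower number from compound 2 to compound 3 (1.03 log units; beyond the scatter), so this single place on the ring has a large bearing on the read-out, which the earlier pair could not show, since it swapped the whole ring substitution at once. Carrying a bromo does not by itself settle the number, as 3-bromo-4-methoxyphenyl in place of 4-bromophenyl gives a 5.8-fold lower number from compound 1 to compound 3 (0.76 log units; beyond the scatter), a modest gain that shows the two bromo-bearing benzyl groups are not interchangeable. The step from compound 2 rests on a limit and not on a number: the limit of > 20000 nM in this assay, at which 1 of the 3 values shown sits.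

The compounds shown leave open whether the gain belongs to bromo itself or would also come with chloro, methyl or trifluoromethyl on the same carbon. They also leave open how much the methoxy in compound 3 contributes, a question that a plain 3-bromobenzyl group would address by separating it from the shift in the place of the bromo.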